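This account rests on a few compounds, and the source may have more. Where it says the series, first, only, none or still open, it means among the compounds named here.

In a functional assay on HCC 2998 cells (Homo sapiens) for inhibition, read by sulforhodamine B assay, with a stated time of 48 h (on this read-out lower numbers stand for stronger inhibition of growth and higher numbers for weaker inhibition of growth), the three measured compounds stand as follows:

compound 1 `COc1cc(-c2nn(-c3cccc(NC(=O)Nc4ccc(Cl)c(Cl)c4)c3)cc2-c2ccncc2)ccc1Cl` gives 6200 nM
compound 2 `O=C(Nc1cccc(-n2cc(-c3ccncc3)c(-c3ccc(Cl)c(O)c3)n2)c1)Nc1ccc(Cl)c(Cl)c1` gives 13900 nM
compound 3 `COc1cc(-c2nn(-c3cccc(NC(=O)Nc4ccc(Cl)c(C(F)(F)F)c4)c3)cc2-c2ccncc2)ccc1Cl` gives 7300 nM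

Compound 2 differs from compound 1 by hydrogen in place of methyl on an oxygen on an aromatic ring, and this change produced a 2.2-fold higher number from compound 1 to compound 2 (0.35 log units; beyond the scatter). Compound 3 differs from compound 1 by trifluoromethyl in place of chloro on an aromatic carbon, a change that gave a 1.2-fold higher number from compound 1 to compound 3 (0.07 log units; within the scatter), so compound 1 and compound 3 cannot be told apart in this assay.

Compound 4 `O=C(Nc1cccc(-n2cc(-c3ccncc3)c(-c3ccc(Cl)c(O)c3)n2)c1)Nc1ccc(Cl)c(C(F)(F)F)c1` has not yet been measured. It differs from compound 3 by hydrogen in place of methyl on an oxygen on an aromatic ring. This is the same change that separates compound 1 from compound 2, the place of the change being described in the same words for both pairs; it occurs twice among the compounds shown. Going by the values given here, because a 1.2-fold higher number from compound 1 to compound 3 (0.07 log units; within the scatter) leaves compound 1 and compound 3 within the scatter of each other in this assay, and because the single earlier instance of the change gave a 2.2-fold higher number from compound 1 to compound 2 (0.35 log units; beyond the scatter), a step of similar size is expected for compound 4, that is, a 2.1-fold higher number from compound 3 to compound 4 (0.33 log units; beyond the scatter). Compound 4 is therefore estimated at 15500 nM, with a likely range from 8000 nM to 32000 nM.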

Compound 4, concentration for total growth inhibition: 4120 nM
Beside the measured number, compound 4's estimate is 3.8-fold (0.58 log units) above it; the measured number lies below the stated range.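

In this assay, methoxy to hydroxy on the core of compound 3 gave a 1.8-fold lower number from compound 3 to compound 4 (0.25 log units; within the scatter), and this step does not match the one seen on the core of compound 1: the same change on two cores in this assay, a 2.2-fold higher number (0.35 log units; beyond the scatter) from compound 1 to compound 2 and a 1.8-fold lower number (0.25 log units; within the scatter) from compound 3 to compound 4, 4.0-fold (0.60 log units) apart, beyond the scatter of two such steps
The other change also failed to carry over, since trifluoromethyl in place of chloro gave a 3.4-fold lower number from compound 2 to compound 4 (0.53 log units; beyond the scatter) among the hydroxy compounds, unlike its step among the methoxy compounds: the same change on two cores in this assay, a 1.2-fold higher number (0.07 log units; within the scatter) from compound 1 to compound 3 and a 3.4-fold lower number (0.53 log units; beyond the scatter) from compound 2 to compound 4, 4.0-fold (0.60 log units) apart, beyond the scatter of two such steps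
Going by these compounds alone, these four compounds therefore show that neither step can be moved unchanged from one core to the other, so the result for a hydroxy and trifluoromethyl pairing cannot be predicted by adding the two separate steps, but they do not show why, and with only one pair of steps for each change they establish no general rule for the series.

The compounds shown leave open how an ethoxy group or an amine would behave in place of the methoxy or hydroxy group. They also leave open whether a nitrile in place of the chloro or trifluoromethyl group would follow compound 2 and compound 4 or the methoxy pair.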